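This account rests on a few compounds, and the source may have more. Where it says the series, first, only, none or still open, it means among the compounds named here.

Measured compounds:
compound 1, `COCCNc1nc(C)nc2c1nnn2-c1c(C)cc(C)cc1C`, 1200 nM
compound 2, `CCCCC(CC)Nc1nc(C)nc2c1nnn2-c1c(C)cc(C)cc1C`, 7.6 nM
compound 3, `Cc1nc(N2CCCC2)c2nnn(-c3ccc(C(C)C)cc3Br)c2n1`, 194 nM

In an in vitro assay on 293-EBNA cells for binding affinity to corticotropin-releasing factor receptor 1 (Homo sapiens) (on this read-out higher numbers stand for weaker inhibition and lower numbers for stronger inhibition), compound 3 stands second highest of the three numbers, nearer to compound 1 and far from compound 2. Compound 4, `CCCCNc1nc(C)nc2c1nnn2-c1ccc(C(C)C)cc1Br`, differs from compound 3 in one place: butylamino in place of pyrrolidin-1-yl on an aromatic carbon.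

Within the data shown here, no measured step covers this exchange of a ring amine for an open-chain amine. Among the measured compounds shown here, the one step on record, a 160-fold lower number from compound 1 to compound 2 (2.20 log units; beyond the scatter), shows instead that the chain on the amino nitrogen can move this assay by a large amount, with the longer, branched 1-ethylpentyl chain giving the far lower number. Butylamino is an open chain of the same kind as in compound 2, though without branching, and it carries one hydrogen-bond donor that pyrrolidin-1-yl lacks; how much of the gap between compound 3 and compound 2 this alone closes is not shown. A moderate step downward from compound 3 is therefore expected, a 3.2-fold lower number from compound 3 to compound 4 (0.51 log units; beyond the scatter), with wide uncertainty. For compound 4 in this assay the estimate is 60 nM, expected to lie between 15 nM and 250 nM.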

Compound 4, inhibition constant: 69.6 nM
The estimate for compound 4 lay 1.2-fold (0.06 log units) below the measured number; the range from low to high includes it.
By their numbers in this assay, from the lowest: compound 2; then compound 4; then compound 3; then compound 1.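

In this assay, among these compounds, the exchange of pyrrolidin-1-yl for butylamino, on the aromatic carbon next to the ring nitrogen, gives a 2.8-fold lower number from compound 3 to compound 4 (0.45 log units; beyond the scatter) and is the first reading of a ring amine against an open-chain amine at this position. The two groups match in heavy atoms, so the step shows that opening the ring and adding a hydrogen-bond donor, with no change in that count, moves the number beyond the scatter, though only modestly. Set beside a 160-fold lower number from compound 1 to compound 2 (2.20 log units; beyond the scatter), an exchange of one open chain for another, it is much the smaller step, and nothing measured here gives a reason for it.

The compounds shown leave open whether the amino hydrogen or the open chain accounts for the step, a question that a butyl(methyl)amino group or a piperidin-1-yl group at the same place could bear on. From the compounds shown here alone, compound 2 and compound 4 differ in more than one place, so how the branched 1-ethylpentyl chain would read on the core of compound 4, against its unbranched butylamino, also remains open.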